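The source may report more compounds than this note shows. Statements on the series, on what has been measured and on what is new or still open speak of the compounds shown alone.

The three measured compounds share one core and differ only in the aryl group on the ring nitrogen. Compound 1 `Cc1cc(=O)n(-c2cccc(F)c2)nc1C(=O)Nc1ccc(Oc2ncnc3sccc23)cc1` in a functional assay on MCF7 cells (Homo sapiens) for cytotoxicity, read by MTT assay, with a stated time of 72 h (a higher number here means a weaker inhibitor, a lower number a stronger inhibitor), gives 27200 nM. Compound 3 `Cc1cc(=O)n(-c2ccc(F)cc2)nc1C(=O)Nc1ccc(Oc2ncnc3sccc23)cc1` gives 21000 nM in this assay. Compound 2 `Cc1ccc(-n2nc(C(=O)Nc3ccc(Oc4ncnc5sccc45)cc3)c(C)cc2=O)cc1` gives in this assay only a limit of the assay, > 40000 nM. Compound 2 is thus the one sitting at the limit of > 40000 nM in this assay, at which 1 of the 3 values shown sits. Among the measured steps, 4-fluorophenyl in place of 3-fluorophenyl gives a 1.3-fold lower number from compound 1 to compound 3 (0.11 log units; within the scatter), 4-methylphenyl in place of 3-fluorophenyl gives an at least 1.4-fold higher number from compound 1 to compound 2 (0.16 log units; that floor lies within the scatter), and fluoro in place of methyl on that aryl ring gives an at least 1.9-fold lower number from compound 2 to compound 3 (0.27 log units; that floor lies within the scatter); each of these lies within the scatter.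

Compound 4 `Cc1ccc(-n2nc(C(=O)Nc3ccc(Oc4ncnc5sccc45)c(F)c3)c(C)cc2=O)cc1` has not yet been measured. It differs from compound 2 by fluoro in place of hydrogen on an aromatic carbon, the fluorine sitting on an aromatic carbon of a six-membered aromatic ring of carbon only, ortho to a large group and meta to a large group. Among the measured compounds shown here, none of the measured steps touches this ring; all three concern the aryl group on the ring nitrogen, and none of them went beyond the scatter. The expected step is therefore one of no change beyond the scatter, a number no higher from compound 2 to compound 4 (the limit leaves the size open). Compound 4 is expected at about 40000 nM, in the range 15000 nM to 100000 nM, with a real chance that this assay again returns only a limit.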

Compound 4, half-maximal inhibitory concentration: > 40000 nM
Compound 4 was reported as a limit; the forecaster's own chance of this, stated with the estimate: 60%; the middle value sits exactly at the limit.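

No step can be read from compound 2 to compound 4, as both stand in this assay only as limits of the assay: the limit of > 40000 nM in this assay, at which 2 of the 4 values shown sit.

The compounds shown leave open whether fluoro in place of hydrogen on this aromatic carbon changes the number in this assay at all, and in which direction.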